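The source may hold more compounds than are shown below. What is called first, only, known or untested is meant among the compounds shown, and "the series" means these compounds.

Of the compounds shown here, three built on one shared core have been measured in a functional assay on HepG2 cells (Homo sapiens) for antiproliferative activity, read by sulforhodamine B assay, with a stated time of 3 days; a higher number here means that more compound is needed for the effect, a lower number that less compound is needed. Compound 1 `CCCC1=C(OC)C(CCC)(CCC)C(=O)/C(=C(O)\C=C\c2ccc(I)cc2)C1=O` gives 2.4 uM. Compound 2 `CCCC1=C(OCC)C(CCC)(CCC)C(=O)/C(=C(O)\C=C\c2ccccc2)C1=O` gives 11.2 uM. Compound 3 `CCCCC1=C(OC)C(CCCC)(CCCC)C(=O)/C(=C(O)\C=C\c2ccccc2)C1=O` gives 23.9 uM. Among these three numbers compound 2 holds the second highest: the nearest is compound 3, whose number is higher by a gap beyond the usual scatter, and the furthest is compound 1, whose number is lower by a gap also beyond the scatter. Compound 4 `CCCCOC1=C(CCC)C(=O)/C(=C(O)/C=C/c2ccccc2)C(=O)C1(CCC)CCC` has not yet been measured. It differs from compound 2 in one place: ethyl in place of hydrogen on a saturated chain carbon, two bonds along the chain from an oxygen on an unsaturated carbon. Going by the values given here, no pair of measured compounds differs in exactly this way, so there is no measured step of this kind to lean on. The expected step is a 1.3-fold higher number from compound 2 to compound 4 (0.13 log units; within the scatter), pointing toward a higher number but small enough that it may well stay within the scatter. Compound 4 is therefore estimated to give about 15 uM in this assay, with a likely range from 6 uM to 40 uM.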

Compound 4, concentration for half-maximal effect: 8 uM
The estimate for compound 4 lay 1.9-fold (0.27 log units) above the measured number; the range from low to high includes it.
By their numbers in this assay, from the lowest: compound 1; then compounds 4 and 2 (each within the scatter of the next); then compound 3.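

In this assay, extending the ethoxy of compound 2 to the butoxy of compound 4 gives a 1.4-fold lower number from compound 2 to compound 4 (0.15 log units; within the scatter) and so the two compounds cannot be told apart in this read-out. Going by these compounds alone, this is the first direct look at this position, and it shows that an ethyl added on a saturated chain carbon, two bonds along the chain from an oxygen on an unsaturated carbon, leaves the number where repeated measurement could put it anyway. Nothing in the data shown gives a reason for this result.

On these data alone, whether a longer chain such as hexyloxy, or a chain ending in an amine or a carboxylic acid, would also stay this close remains open. So does whether the change from ethoxy to butoxy would behave alike in a compound carrying the iodine of compound 1.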